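A Cyclopropyl Group Replaces a Long Amine Substituent

The compounds below may be only part of what the source reports. "The series", "measured", "known", "first", "only" and "open" are said of these compounds alone.

Compound 1 `COc1ccc(CNCc2c(OC)cc(Oc3cccc(Nc4ccccc4)c3)cc2OC)cc1`: 2620 nM
Compound 2 `COc1cc(Oc2cccc(Nc3ccccc3)c2)cc(OC)c1CNCc1ccccc1`: 4070 nM
Compound 3 `COc1ccc(CCCNCc2c(OC)cc(Oc3cccc(Nc4ccccc4)c3)cc2OC)cc1`: 2850 nM

These three values come from a functional assay on HCT-116 cells (Homo sapiens) for inhibition, read by MTT assay, with a stated time of 72 h (on this read-out higher numbers stand for weaker inhibition and lower numbers for stronger inhibition), and they all lie within the scatter of one another. Compound 3, at 2850 nM, therefore cannot be separated from the other two. Compound 4 `COc1cc(Oc2cccc(Nc3ccccc3)c2)cc(OC)c1CNC1CC1` keeps the shared core but has a different group on the amine nitrogen: cyclopropyl in place of 3-(4-methoxyphenyl)propyl on an amine nitrogen. In short, cyclopropyl stands in place of 3-(4-methoxyphenyl)propyl.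

Two measured steps change the group at this same part of the molecule: a 1.1-fold higher number from compound 1 to compound 3 (0.04 log units; within the scatter), and a 1.4-fold lower number from compound 2 to compound 3 (0.15 log units; within the scatter). A third step, a 1.6-fold higher number from compound 1 to compound 2 (0.19 log units; within the scatter), is also small. Among the measured compounds shown here, all three groups carry a six-membered aromatic ring of carbon only, and no measured compound shows how a cyclopropyl group behaves. The evidence therefore points to no step beyond the scatter, but only loosely, so the range must stay wide. The expected step is a 1.2-fold higher number from compound 3 to compound 4 (0.09 log units; within the scatter). For compound 4 the estimated value is 3500 nM, with an expected range from 1500 nM to 8500 nM.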

Compound 4, half-maximal inhibitory concentration: > 20000 nM
Compound 4 gave a limit, no number; the forecaster's own chance of this, stated with the estimate: 5%; at least 5.7-fold (0.75 log units) between middle value and limit.
By their numbers in this assay, from the lowest: compounds 1, 3 and 2 (each within the scatter of the next). At a limit, above all of these: compound 4.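

In this assay compound 4 gives > 20000 nM, which is a limit of the assay and not a number. Among the compounds shown here, the earlier changes on the amine nitrogen all stayed within the scatter, whereas cyclopropyl gives the first steps beyond it: an at least 7.0-fold higher number from compound 3 to compound 4 (0.84 log units; beyond the scatter), an at least 4.9-fold higher number from compound 2 to compound 4 (0.69 log units; beyond the scatter) and an at least 7.6-fold higher number from compound 1 to compound 4 (0.88 log units; beyond the scatter). So the group on this nitrogen does matter: compounds 1, 2 and 3, which all carry a six-membered aromatic ring of carbon only there, sit together, and compound 4, without that ring, stands apart.

On these data alone, how far compound 4 truly lies from the others stays open, since only a limit is available: the limit of > 20000 nM in this assay, at which 1 of the 4 values shown sits. Also open is whether the aromatic ring itself counts or simply the number of heavy atoms, which a cyclohexyl group or a plain butyl chain on the amine nitrogen could help separate.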